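Methoxy for bromo on the shared core

A few compounds are considered here, and "the series" means these few. Any claim that something is new, unique, unknown or untested is made for them only; others in the source may bear on it.

Within the data shown here, compound 3 `N#CC1=C(N)Oc2c(N)cc3nc4ccccc4nc3c2C12C(=O)N(Cc1cnnn1-c1ccccc1Br)c1ccccc12` is the only member of the set with a number in a functional assay on HepG2 cells (Homo sapiens) for antiproliferative activity, read by MTT assay, with a stated time of 48 h; on this read-out lower numbers stand for stronger inhibition and higher numbers for weaker inhibition: compound 3 gives 38000 nM. Compound 1 `Cc1ccccc1-n1nncc1CN1C(=O)C2(C(C#N)=C(N)Oc3c(N)cc4nc5ccccc5nc4c32)c2ccccc21` reaches only a limit of the assay, > 50000 nM. Compound 2 `Cc1cccc(-n2nncc2CN2C(=O)C3(C(C#N)=C(N)Oc4c(N)cc5nc6ccccc6nc5c43)c3ccccc32)c1` likewise reaches only a limit, > 50000 nM. The two limits sit at the limit of > 50000 nM in this assay, at which 2 of the 3 values shown sit, so the step that the two limits leave unreadable from compound 1 to compound 2 is unreadable, while the steps of an at least 1.3-fold lower number from compound 1 to compound 3 (0.11 log units; that floor lies within the scatter) and an at least 1.3-fold lower number from compound 2 to compound 3 (0.11 log units; that floor lies within the scatter) have floors that lie within the scatter.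

Compound 4 `COc1ccccc1-n1nncc1CN1C(=O)C2(C(C#N)=C(N)Oc3c(N)cc4nc5ccccc5nc4c32)c2ccccc21` differs from compound 3 by methoxy in place of bromo on an aromatic carbon. Among the measured compounds shown here, the steps that bear on this change are those that alter the same substituent on the same ring, from compound 1 and from compound 2 to compound 3; both are read only as floors within the scatter, and neither tells how a methoxy group behaves here. No step beyond the scatter is therefore expected in this assay for compound 4, in either direction, though a result that is again a limit is a real possibility. The estimate for compound 4 is 45000 nM, with a range from 20000 nM to 120000 nM. The step this estimate means is a 1.2-fold higher number from compound 3 to compound 4 (0.07 log units; within the scatter), an expected change that stays within the scatter.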

Compound 4, half-maximal inhibitory concentration: > 50000 nM
Compound 4 gave a limit, no number (the forecaster's own chance of this, stated with the estimate: 50%); middle value at least 1.1-fold (0.04 log units) away from the limit.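

In this assay, 2-methoxyphenyl joins 2-methylphenyl and 3-methylphenyl at the assay limit, so 2-bromophenyl in compound 3 remains the only group in the set with a number: the limit of > 50000 nM in this assay, at which 3 of the 4 values shown sit.

Methoxy in place of bromo, on an aromatic carbon ortho to a large group, gives an at least 1.3-fold higher number from compound 3 to compound 4 (0.11 log units; that floor lies within the scatter), so this change, like bromo in place of methyl, can be read only as a floor that does not separate the two groups. The steps from compound 1 and from compound 2 to compound 4 join two limits and cannot be read.

Going by these compounds, how far compounds 1, 2 and 4 lie past the limit remains unknown. Also open, on these data alone, is whether an amine or a carboxylic acid at this place would give a number beyond the scatter from compound 3.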